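This account rests on a few compounds, and the source may have more. Where it says the series, first, only, none or still open, it means among the compounds named here.

Measured in a functional assay on V79-379A cells (Cricetulus griseus) for cytotoxicity, read by MTT assay, in the presence of a further agent that is not named here; on this read-out higher numbers stand for weaker inhibition and lower numbers for stronger inhibition:
- compound 1 `COC1=CC(=O)c2c(c(COC(=O)c3ccccc3)c(C)n2C)C1=O`: 16000 nM
- compound 2 `COC1=CC(=O)c2c(c(COCc3ccccc3)c(C)n2C)C1=O`: 225000 nM
- compound 3 `COC1=CC(=O)c2c(c(COC(C)=O)c(C)n2C)C1=O`: 27000 nM

Compound 3 cannot be separated from compound 1, since the gap is a 1.7-fold higher number from compound 1 to compound 3 (0.23 log units; within the scatter). Its number is clearly lower than that of the third compound, with an 8.3-fold lower number from compound 2 to compound 3 (0.92 log units; beyond the scatter). Among these three, the two compounds carrying an acyl group on the oxygen have the lower numbers, and none goes against this.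

Compound 4 `COC1=CC(=O)c2c(c(COc3ccccc3)c(C)n2C)C1=O` keeps the shared core and has phenyl in place of acetyl on an oxygen on a saturated carbon. Among the measured compounds shown here, no measured step places phenyl directly on that oxygen. The nearest evidence comes from replacing an acyl group with benzyl, which gave a 14-fold higher number from compound 1 to compound 2 (1.15 log units; beyond the scatter). The same comparison read in reverse, from benzyl to acetyl, gave an 8.3-fold lower number from compound 2 to compound 3 (0.92 log units; beyond the scatter). Compound 4 also loses the acyl group, but phenyl is not benzyl, so only part of that large change is expected to carry over in this assay. The expected shift is modest and towards a higher number, though it may stay within the scatter. The estimated change is a 1.9-fold higher number from compound 3 to compound 4 (0.27 log units; within the scatter). For compound 4 the expected value is 50000 nM, with an estimated range of 13000 nM to 200000 nM.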

Compound 4, half-maximal inhibitory concentration: 12000 nM
For compound 4 the middle estimate is 4.2-fold (0.62 log units) above the measured one, and the stated range ends above it.
By their numbers in this assay, from the lowest: compounds 4, 1 and 3 (each within the scatter of the next, the first and the last beyond it); then compound 2.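

In this assay, phenyl in place of acetyl on the oxygen gave a 2.3-fold lower number from compound 3 to compound 4 (0.35 log units; beyond the scatter), so compound 4 goes against the earlier link between an acyl group on this oxygen and a low number, and such a group is not required for one. Compound 4 also cannot be separated from the benzoyl compound, with a 1.3-fold lower number from compound 1 to compound 4 (0.12 log units; within the scatter), even though it has no carbonyl at this place. Phenyl in place of benzyl gave a 19-fold lower number from compound 2 to compound 4 (1.27 log units; beyond the scatter), so losing the acyl group does not by itself produce the high number of compound 2, and among these four compounds that number goes with the benzyl group alone.

No measured property is available here to explain why phenyl and benzyl on this oxygen read so differently. From the compounds shown here alone, it remains open how this assay would respond to a longer chain ending in phenyl, such as phenethyl, on this oxygen, to an amine in place of the oxygen, or to a methoxy or chloro group on the phenyl ring of compound 4.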